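The compounds below may be only part of what the source reports. "The series", "measured", "known", "first", "only" and "open" are said of these compounds alone.

Compound 1 `COCc1cc(-c2cnn(C)c2-c2sc3ccccc3c2C#N)cc2c(CN)n[nH]c(=O)c12` gives 19 nM
Compound 2 `Cn1ncc(-c2cc(C(F)F)c3c(=O)[nH]nc(CN)c3c2)c1-c1sc2ccccc2c1C#N` gives 37 nM

Within the data shown here, both numbers come from a functional assay on HCT-116 cells (Homo sapiens) for antiproliferative activity, read by CellTiter-Glo, with a stated time of 10 days (on this read-out higher numbers stand for weaker inhibition and lower numbers for stronger inhibition), and these are the only two compounds measured there so far. Compound 2 stands level with compound 1 within the normal scatter of repeat measurements. Among the measured compounds shown here, the only measured step is a 1.9-fold higher number from compound 1 to compound 2 (0.29 log units; within the scatter) and it comes with difluoromethyl in place of methoxymethyl on an aromatic carbon.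

Compound 3 `CCOc1cc(-c2cnn(C)c2-c2sc3ccccc3c2C#N)cc2c(CN)n[nH]c(=O)c12` has not yet been measured. It keeps the core of compound 2 but carries ethoxy in place of difluoromethyl on an aromatic carbon. This is the same carbon that changed between compound 1 and compound 2, and the swap there gave a 1.9-fold higher number from compound 1 to compound 2 (0.29 log units; within the scatter) and so no shift beyond the scatter. One step is thin evidence, and ethoxy itself has not been tested on this core. Even so, no step beyond the scatter is expected in this assay for this change. The estimated step is a 1.5-fold lower number from compound 2 to compound 3 (0.17 log units; within the scatter) and it would be too small to read as a real difference. For compound 3 the estimated value is 25 nM with an expected range of 10 nM to 65 nM in this read-out.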

Compound 3, half-maximal inhibitory concentration: 150 nM
Compound 3: middle estimate off by 6.0-fold (0.78 log units), on the low side; the whole stated range lies below it.
By their numbers in this assay, from the lowest: compounds 1 and 2 (each within the scatter of the next); then compound 3.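

In this assay, this aromatic carbon turns out not to accept every small group equally: ethoxy in place of difluoromethyl gives a 4.1-fold higher number from compound 2 to compound 3 (0.61 log units; beyond the scatter) and stands as a modest but real change. Ethoxy in place of methoxymethyl gives a 7.9-fold higher number from compound 1 to compound 3 (0.90 log units; beyond the scatter) and also lies beyond the scatter, whereas the only earlier step at this carbon, a 1.9-fold higher number from compound 1 to compound 2 (0.29 log units; within the scatter), did not, so the first two compounds alone gave no sign that a change here could matter. Difluoromethyl and ethoxy each have 3 heavy atoms, so that count does not separate them, and no measurement at hand explains the step.

Ethoxy joins the aromatic carbon through its oxygen, while difluoromethyl and methoxymethyl join it through carbon, but these three compounds cannot show whether that link or the ethyl chain goes with the higher number. A methoxy group, an amine or a propyl chain on the same carbon of the shared core would help separate these two readings, and a longer alkoxy chain would show whether the number keeps rising with chain length.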